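The source may hold more compounds than are shown below. What is called first, only, known or untested is meant among the compounds shown, and "the series" means these compounds.

Compound 1 `CC[C@@H](CCn1cncn1)c1ccc(Cl)cc1` gives 55.1 ug/mL in an ADME assay on HEp-2 cells (Homo sapiens) for cytotoxicity, read by MTT assay, with a stated time of 3 days; on this read-out lower numbers stand for higher toxicity in this test and higher numbers for lower toxicity in this test. Compound 2 `CC[C@@H](CCn1cncn1)c1ccc(OC)cc1` carries methoxy in place of chloro on an aromatic carbon, and in this assay compound 2 gives 146 ug/mL, so that a 2.6-fold higher number from compound 1 to compound 2 (0.42 log units; beyond the scatter). Compound 3 `CCCC[C@H](CCn1cncn1)c1ccc(Cl)cc1` shares the core of compound 1 only in part; the difference between the two cores is not broken down here. In this assay compound 3 gives 20.2 ug/mL, the lowest number among the three measured compounds, beyond the scatter from each of the other two. Compound 4 `CCCC[C@H](CCn1cncn1)c1ccc(OC)cc1` stands to compound 3 as compound 2 stands to compound 1, carrying methoxy in place of chloro on an aromatic carbon at a place described in the same words. Because the earlier pair showed a 2.6-fold higher number from compound 1 to compound 2 (0.42 log units; beyond the scatter), a step of about the same size is expected here, a 2.6-fold higher number from compound 3 to compound 4 (0.41 log units; beyond the scatter). Compound 4 is therefore estimated at 52 ug/mL in this assay, with a likely range from 30 ug/mL to 90 ug/mL.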

Compound 4, half-maximal cytotoxic concentration: 34.5 ug/mL
Estimate against measurement, compound 4: 1.5-fold (0.18 log units) above; measured number inside the range.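

In this assay, methoxy in place of chloro on an aromatic carbon gives a 1.7-fold higher number from compound 3 to compound 4 (0.23 log units; within the scatter), and the two steps on the two cores do not differ beyond the scatter: the same change on two cores in this assay, a 2.6-fold higher number (0.42 log units; beyond the scatter) from compound 1 to compound 2 and a 1.7-fold higher number (0.23 log units; within the scatter) from compound 3 to compound 4, 1.6-fold (0.19 log units) apart, within the scatter of two such steps. The two steps are thus compatible with a single shift carried from the core of compound 1 to the core of compound 3, although the step on the core of compound 3 cannot on its own be told from the scatter. Two pairs do not show that the step has a fixed size on other cores, and they do not explain it.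

The compounds shown leave open what a nitrile or an amine in place of chloro would do on these cores. They also leave open whether the methoxy step would hold with a longer chain on the core.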